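Lengthening the Amine Chain: What Compound 4 May Dissolve

A few compounds are considered here, and "the series" means these few. Any claim that something is new, unique, unknown or untested is made for them only; others in the source may bear on it.

Of the compounds shown here, three built on one shared core have been tested in a physicochemical assay for solubility, in phosphate buffer; on this read-out lower numbers stand for lower solubility and higher numbers for higher solubility. Compound 2 `CNC1CC(=O)OC1C(O)C(=O)NC(CC(C)C)C1Cc2cccc(O)c2C(=O)O1` gives 990 ug/mL, compound 1 `CCCNC1CC(=O)OC1C(O)C(=O)NC(CC(C)C)C1Cc2cccc(O)c2C(=O)O1` gives 1600 ug/mL, and compound 3 `CCCCNC1CC(=O)OC1C(O)C(=O)NC(CC(C)C)C1Cc2cccc(O)c2C(=O)O1` gives 370 ug/mL. Compound 2 thus stands second highest of the three: a 1.6-fold lower number from compound 1 to compound 2 (0.21 log units; within the scatter) lies within the scatter, while a 2.7-fold lower number from compound 2 to compound 3 (0.43 log units; beyond the scatter) lies beyond it. The unmeasured compound 4 `CCCCCCNC1CC(=O)OC1C(O)C(=O)NC(CC(C)C)C1Cc2cccc(O)c2C(=O)O1` differs from compound 2 by pentyl in place of hydrogen on a saturated chain carbon bound to an amine nitrogen. The closest guide is a 2.7-fold lower number from compound 2 to compound 3 (0.43 log units; beyond the scatter), the same kind of change at the same place, and a 4.3-fold lower number from compound 1 to compound 3 (0.64 log units; beyond the scatter) also lowered the number. A lower number is therefore expected for compound 4 because of a 2.7-fold lower number from compound 2 to compound 3 (0.43 log units; beyond the scatter), estimated as a 12-fold lower number from compound 2 to compound 4 (1.09 log units; beyond the scatter). Compound 4 is expected to give 80 ug/mL, with a range from 20 ug/mL to 300 ug/mL.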

Compound 4, solubility: 5 ug/mL
The estimate for compound 4 lay 16-fold (1.20 log units) above the measured number, outside the stated range (below it).
By their numbers in this assay, from the lowest: compound 4; then compound 3; then compounds 2 and 1 (each within the scatter of the next).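

On this assay the hexylamino group of compound 4 brings far larger drops than any earlier step, with a 200-fold lower number from compound 2 to compound 4 (2.30 log units; beyond the scatter) and a 320-fold lower number from compound 1 to compound 4 (2.51 log units; beyond the scatter) both rated large. The fall is uneven along the chain: compound 1 and compound 2 lie within the scatter of each other, yet a 74-fold lower number from compound 3 to compound 4 (1.87 log units; beyond the scatter) is the sharpest single step of the series. Nothing available explains why the number falls so steeply here. Still open, on these data alone, is how a chain longer than hexyl would read, and whether a hexyl chain ending in a carboxylic acid or an amine would give a number nearer that of compound 3.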